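The source may hold more compounds than are shown below. What is called first, only, known or untested is meant among the compounds shown, and "the series" means these compounds.

Measured compounds:
compound 1, `Oc1ccc(-c2cc(-c3cccs3)cc(-c3cccc(O)c3)n2)cc1`, in a functional assay on T47D cells (Homo sapiens) for cytotoxicity, read by CCK-8 assay (a higher number here means a weaker inhibitor, a lower number a stronger inhibitor), gives 780 nM
compound 2, `Oc1cccc(-c2cc(-c3ccccn3)cc(-c3ccccc3O)n2)c1`, in this assay gives 2560 nM

Compound 2 stands at the higher of these two numbers; compound 1 lies at a lower number, and the gap between them is beyond the usual scatter. Compound 3, `Oc1ccc(-c2cc(-c3ccccn3)cc(-c3cccc(O)c3)n2)cc1`, is not yet measured. It differs from compound 2 by 4-hydroxyphenyl in place of 2-hydroxyphenyl on an aromatic carbon. Compound 1 carries the 4-hydroxyphenyl arrangement and gives 780 nM, so compound 3 is expected to move toward a lower number. The step from compound 2 to compound 3 is estimated as a 2.1-fold lower number from compound 2 to compound 3 (0.33 log units; beyond the scatter). Compound 3 is expected to give about 1200 nM, with a plausible range from 400 nM to 3500 nM.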

Compound 3, half-maximal inhibitory concentration: 980 nM
Beside the measured number, compound 3's estimate is 1.2-fold (0.09 log units) above it, and the stated range covers the measured number.
By their numbers in this assay, from the lowest: compounds 1 and 3 (each within the scatter of the next); then compound 2.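

In this assay, 4-hydroxyphenyl in place of 2-hydroxyphenyl next to the ring nitrogen gives a 2.6-fold lower number from compound 2 to compound 3 (0.42 log units; beyond the scatter), so with the same atoms, the attachment point of the hydroxyl on this phenyl ring alone shifts the number. Pyridin-2-yl in place of thiophen-2-yl gives a 1.3-fold higher number from compound 1 to compound 3 (0.10 log units; within the scatter), within the scatter, so the gap between the two earlier compounds follows the hydroxyphenyl change in this set. Nothing available explains this shift. From the compounds shown here alone, whether a methoxy group or an amine in place of this hydroxyl would keep the lower number remains open.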